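Cyclohexylamino replacing 3-aminocyclohexyl on the shared core

This account rests on a few compounds, and the source may have more. Where it says the series, first, only, none or still open, it means among the compounds named here.

Compound 1 `CCCn1c(=O)c2nc(C3CCCC(N)C3)[nH]c2n(CCC)c1=O` gives 50 nM in a functional assay for antagonist activity at adenosine receptor A1 (Homo sapiens) (on this read-out lower numbers stand for stronger inhibition and higher numbers for weaker inhibition), the higher of the two single numbers in the series; its nearest neighbour is compound 3 `CCCn1c(=O)c2nc(C3CCCC(NC(C)=O)C3)[nH]c2n(CCC)c1=O` at 41 nM, and the step of a 1.2-fold lower number from compound 1 to compound 3 (0.09 log units; within the scatter) puts acetyl in place of hydrogen on an amine nitrogen. Compound 2 `CCCn1c(=O)c2nc(C3CCC(NC(C)=O)CC3)[nH]c2n(CCC)c1=O` gives 70 nM; 12 nM (2 entries) in this assay; the several entries of compound 2 in this assay, 70 nM; 12 nM (2 entries) leaves compound 2 without a single number. Compound 4 `CCCn1c(=O)c2nc(NC3CCCCC3)[nH]c2n(CCC)c1=O` differs from compound 1 by cyclohexylamino in place of 3-aminocyclohexyl on an aromatic carbon. Going by the values given here, no measured step covers this exchange; the only measured step, a 1.2-fold lower number from compound 1 to compound 3 (0.09 log units; within the scatter), alters the amine and stays within the scatter, so it gives no direction for the new linkage. For compound 4 a modest step of a 2.0-fold higher number from compound 1 to compound 4 (0.30 log units; within the scatter) toward a weaker number is expected, estimated at 100 nM with a range from 20 nM to 500 nM.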

Compound 4, inhibition constant: 14 nM
For compound 4 the middle estimate is 7.1-fold (0.85 log units) above the measured one; the whole stated range lies above it.
By their numbers in this assay, from the lowest: compound 4; then compounds 3 and 1 (each within the scatter of the next).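

Going by these compounds alone, in the assay (this assay), cyclohexylamino on this aromatic carbon gives the first step beyond the scatter (a 3.6-fold lower number from compound 1 to compound 4 (0.55 log units; beyond the scatter)). The two groups carry the same atoms and the same counts, so at this position the number responds to how they are joined: the ring attached through nitrogen rather than directly through a ring carbon. Nothing available here explains the step.

Still open, going by these compounds, is whether an ether oxygen or an N-methylamino linker would hold the number. Also open, on these data alone, is whether a cyclopentylamino or phenylamino group would do the same.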